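The compounds below may be only part of what the source reports. "The series", "measured", "known", "first", "only" and "open" are said of these compounds alone.

Among the compounds with values here, in an ADME assay on a cell-free system (plasma, Homo sapiens) for metabolic stability (on this read-out lower numbers stand for a shorter-lived compound and higher numbers for a longer-lived compound), compound 1 `CCN1C[C@H](C)OC(=O)C1CC(=O)Nc1ccc(C(C)C)cc1` gives 0.95 h, one of only two numbers known so far. Within the data shown here, compound 2 `CCN1C[C@@H](C)OC(=O)C1CC(=O)Nc1ccc(C(C)C)cc1` gives 0.917 h, and the single measured step, a 1.0-fold lower number from compound 1 to compound 2 (0.02 log units; within the scatter), lies within the scatter. Compound 3 `CCN1C[C@H](c2ccccc2)OC(=O)C1CC(=O)Nc1ccc(C(C)C)cc1` has not been measured yet. It differs from compound 1 by phenyl in place of methyl on a saturated ring carbon. Among the measured compounds shown here, the one measured step concerns a different change and bears nothing on this one, so no shift beyond the scatter is expected in this assay. The step expected is a 1.1-fold higher number from compound 1 to compound 3 (0.02 log units; within the scatter). Compound 3 is therefore estimated at 1 h, within a range from 0.5 h to 2.2 h.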

Compound 3, half-life: 0.817 h
Estimate against measurement, compound 3: 1.2-fold (0.09 log units) above; the measured number falls inside the stated range.
By their numbers in this assay, from the lowest: compounds 3, 2 and 1 (each within the scatter of the next).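

In this assay, phenyl in place of methyl on the saturated ring carbon next to the ring oxygen gives a 1.2-fold lower number from compound 1 to compound 3 (0.07 log units; within the scatter). So this carbon can carry a six-membered aromatic ring instead of a single carbon with no change in half-life beyond the scatter, whereas the earlier pair tested only a swap of stereocentre. Nothing on hand bears on this swap of groups. Still open, on these data alone, is whether an amine or a carboxylic acid on this carbon would move the half-life beyond the scatter. Also open, as far as these compounds go, is how phenyl behaves in the opposite configuration.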